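Methyl to Hydrogen on an Aromatic Nitrogen: Two Cases

The source may hold more compounds than are shown below. What is called first, only, known or untested is meant among the compounds shown, and "the series" means these compounds.

Of the compounds shown here, three have been measured in a functional assay on MCF7 cells (Homo sapiens) for cytotoxicity, read by MTT assay, with stated times of 6 h and 48 h; on this read-out higher numbers stand for weaker inhibition and lower numbers for stronger inhibition. Compound 1 `Cn1c(/C=C/C(=O)c2ccc[nH]2)cc(Br)c1Br` gives 450 nM in this assay. Compound 3 `O=C(/C=C/c1cc(Br)c(Br)[nH]1)c1ccc[nH]1` differs from compound 1 in a single place: hydrogen in place of methyl on an aromatic nitrogen. In this assay compound 3 gives 72 nM. That one change produced a 6.3-fold lower number from compound 1 to compound 3 (0.80 log units; beyond the scatter).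

Compound 2 `COc1ccc(OC)c(C(=O)/C=C/c2cc(Br)c(Br)n2C)c1` is built on a different core, and the difference between the two cores is not broken down here. In this assay compound 2 gives 650 nM, the highest of the three numbers; it sits within the scatter of compound 1 and beyond the scatter from compound 3.

Compound 4 `COc1ccc(OC)c(C(=O)/C=C/c2cc(Br)c(Br)[nH]2)c1` has not yet been measured. For the measured compounds named here, it differs from compound 2 by hydrogen in place of methyl on an aromatic nitrogen, the same kind of change as the one from compound 1 to compound 3. The surroundings are not identical: in compound 1 the nitrogen is next to the ring atom that bears a group of 9 heavy atoms, whereas in compound 2 it is next to the ring atom that bears a large group. Going by the values given here, only one measured example of this change exists, so the expectation is held loosely. Because the change once gave a 6.3-fold lower number from compound 1 to compound 3 (0.80 log units; beyond the scatter), a step of similar size, perhaps somewhat smaller, is expected here, namely a 5.0-fold lower number from compound 2 to compound 4 (0.70 log units; beyond the scatter). Compound 4 is therefore expected to give about 130 nM, with a likely range from 50 nM to 350 nM.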

Compound 4, half-maximal inhibitory concentration: 220 nM
The estimate for compound 4 lay 1.7-fold (0.23 log units) below the measured number; the measured number falls inside the stated range.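

Replacing methyl with hydrogen on the aromatic nitrogen of compound 2 gave a 3.0-fold lower number from compound 2 to compound 4 (0.47 log units; beyond the scatter) in this assay, so the number fell on this core as it did on the core of compound 1. Set side by side, the two steps do not differ by more than the usual scatter, which means the change carried over from one core to the other in direction and, as far as these data can tell, in size: the same change on two cores in this assay, a 6.3-fold lower number (0.80 log units; beyond the scatter) from compound 1 to compound 3 and a 3.0-fold lower number (0.47 log units; beyond the scatter) from compound 2 to compound 4, 2.1-fold (0.33 log units) apart, within the scatter of two such steps. This does not show that the step is truly smaller on one core than on the other, it does not explain why the change lowers the number, and, with a single pair on each of two cores in one assay, it does not promise the same result on any further core.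

The compounds shown carry only methyl or hydrogen on this nitrogen, so it remains open what an ethyl group, or a longer chain ending in an amine or a carboxylic acid, would do there. All four compounds also keep both bromo groups, which leaves open whether the step would persist with chloro groups or with hydrogen in their place.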